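From compound 3 to compound 4: a smaller aryl group

The source may hold more compounds than are shown below. What is called first, only, known or untested is meant among the compounds shown, and "the series" means these compounds.

Compound 1 `NCCCCCn1c(SCCc2c[nH]c3ccccc23)nnc1-c1ccc2ccccc2c1` gives 610 nM in an assay on isolated protein for inhibition of somatostatin receptor type 2 (Homo sapiens), tested at 10 uM; on this read-out lower numbers stand for stronger inhibition and higher numbers for weaker inhibition.
Compound 2 `NCCCCn1c(SCCc2c[nH]c3ccccc23)nnc1-c1cnc2ccccc2n1` gives 32 nM in this assay.
Compound 3 `NCCCCn1c(SCCc2c[nH]c3ccccc23)nnc1-c1cc2ccccc2s1` gives 160 nM in this assay.

Compound 3 thus stands second highest of the three numbers: compound 2 lies below it, a 5.0-fold higher number from compound 2 to compound 3 (0.70 log units; beyond the scatter), and compound 1 lies above it. Compound 4 `NCCCCn1c(SCCc2c[nH]c3ccccc23)nnc1-c1cccc(Br)c1` differs from compound 3 in one place: 3-bromophenyl in place of 1-benzothiophen-2-yl on an aromatic carbon. Among the compounds with values here, no measured step swaps a two-ring group for a one-ring group here, so nothing bears directly on this change; the only single-point step, from compound 2 to compound 3, shows that exchanging the aryl group can shift this assay by a modest amount. Compound 4 is therefore expected to give a somewhat higher number than compound 3, a 2.5-fold higher number from compound 3 to compound 4 (0.40 log units; beyond the scatter), with wide uncertainty. The estimate for compound 4 is 400 nM, between 100 nM and 1600 nM.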

Compound 4, inhibition constant: 250 nM
Compound 4: middle estimate off by 1.6-fold (0.20 log units), on the high side; the measured number falls inside the stated range.
By their numbers in this assay, from the lowest: compound 2; then compounds 3 and 4 (each within the scatter of the next); then compound 1.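

With this assay as the read-out, exchanging the two-ring 1-benzothiophen-2-yl for the one-ring 3-bromophenyl on this aromatic carbon gives a 1.6-fold higher number from compound 3 to compound 4 (0.19 log units; within the scatter), so a second ring is not required to hold this level. The quinoxalin-2-yl group stands apart from the one-ring group as well, with a 7.8-fold higher number from compound 2 to compound 4 (0.89 log units; beyond the scatter), and this is the larger of the two aryl steps. Nothing shown explains either step. Still open, on these data alone, is how an unsubstituted phenyl or a pyridyl group would read here, and whether the bromine matters at all.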